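The source may report more compounds than this note shows. Statements on the series, on what has been measured and on what is new or still open speak of the compounds shown alone.

Measured so far:
- compound 1, `CCCCCCc1cc2cn(COCCO)c(=O)nc2o1`: >= 400000 nM
- compound 2, `CCCCCCCC#Cc1cc2cn(COCCO)c(=O)nc2o1`: 200000 nM
- compound 3, `CCCCCCc1cc2cn(COCCO)c(O)nc-2n1`: > 400000 nM

The three compounds share one assay, a functional assay on HEL cells (Homo sapiens), read by microscopy; a higher number here means that more compound is tolerated, a lower number that less compound is tolerated. In it compound 3 gives > 400000 nM, and this is a limit of the assay rather than a number. Compound 1 likewise gives >= 400000 nM, also a limit. Only compound 2 yields a number, 200000 nM. So compound 3 stands where no concentration within the tested range was cytotoxic, alongside compound 1, while compound 2 gives a finite value.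

Compound 4, `CCCCCCCc1cc2cn(COCCO)c(O)nc-2n1`, has not yet been measured in this assay. It differs from compound 3 in one place: methyl in place of hydrogen on a saturated chain carbon, six bonds along the chain from an aromatic carbon. For the measured compounds named here, no step between two measured compounds is recorded that would show what such a lengthening of the chain does here, and the only finite value shown, that of compound 2, stands under a different chain. The account therefore expects no step beyond the usual scatter in this assay from compound 3 to compound 4, with the outcome most likely being another limit.

The estimate for compound 4 in this assay is 400000 nM, ranging from 150000 nM to 800000 nM, and this corresponds to an expected step of a number no higher from compound 3 to compound 4 (the limit leaves the size open).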

Compound 4, minimum cytotoxic concentration: >= 400000 nM
Compound 4 ended at the assay's limit (the forecaster's own chance of this, stated with the estimate: 60%); the middle value lies on the limit itself.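

In this assay, for the compounds shown here, compound 3 and compound 4 both end at limits of the assay rather than at numbers, so no step between the two can be read. The compounds shown leave open whether methyl in place of hydrogen at this place on the chain changes the minimum cytotoxic concentration at all.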